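Notes on the step from compound 3 to compound 4

This account rests on a few compounds, and the source may have more. Where it says the series, first, only, none or still open, it means among the compounds named here.

- Compound 1 `COc1cccc(N2C(=O)COc3ccc(-c4cccc(NS(=O)(=O)c5ccc(F)cc5)c4)cc32)c1` gives > 40000 nM as a limit of the assay, not a number
- Compound 2 `CC(C)N1C(=O)COc2ccc(-c3cccc(NS(=O)(=O)c4ccc(F)cc4)c3)cc21` gives 22700 nM
- Compound 3 `O=C1COc2ccc(-c3cccc(NS(=O)(=O)c4ccc(F)cc4)c3)cc2N1C1CCCCC1` gives 10800 nM
- Compound 4 `Cc1ccc(N2C(=O)COc3ccc(-c4cccc(NS(=O)(=O)c5ccc(F)cc5)c4)cc32)cc1` has not yet been measured

In a functional assay on HeLa cells (Homo sapiens) for antiproliferative activity, read by MTT assay, with a stated time of 72 h (on this read-out lower numbers stand for stronger inhibition and higher numbers for weaker inhibition), compound 3 has the lower of the two true numbers, and a 2.1-fold lower number from compound 2 to compound 3 (0.32 log units; beyond the scatter) is a modest gap beyond the scatter.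

The next change puts 4-methylphenyl in place of cyclohexyl on an amide-type nitrogen in a ring. Among the measured compounds shown here, the closest precedent is compound 1, the only measured compound with a phenyl-type group at this place. Read in reverse, an at least 3.7-fold lower number from compound 1 to compound 3 (0.56 log units; beyond the scatter) suggests that such a swap raises the number in this assay by a step beyond the scatter. The floor of an at least 1.7-fold lower number from compound 1 to compound 2 (0.24 log units; that floor lies within the scatter) lies within the scatter and adds little. Compound 1 carries 3-methoxyphenyl rather than 4-methylphenyl, so this is a single, loose precedent.

The expected step is a 2.3-fold higher number from compound 3 to compound 4 (0.36 log units; beyond the scatter) and points towards weaker inhibition. Compound 4 is estimated at 25000 nM within an expected range from 9000 nM to 60000 nM in this series.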

Compound 4, half-maximal inhibitory concentration: > 40000 nM
Compound 4: a limit, no number; the forecaster's own chance of this, stated with the estimate: 35%; middle value at least 1.6-fold (0.20 log units) away from the limit.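

Putting 4-methylphenyl in place of cyclohexyl on the amide-type nitrogen gives, in this assay, an at least 3.7-fold higher number from compound 3 to compound 4 (0.56 log units; beyond the scatter), so the loss seen with compound 1 is not confined to 3-methoxyphenyl. The floor of an at least 1.7-fold higher number from compound 2 to compound 4 (0.24 log units; that floor lies within the scatter) stays within the scatter and does not yet separate 4-methylphenyl from isopropyl. Among the four compounds, both phenyl-type groups end at the limit of the assay while isopropyl and cyclohexyl give numbers, and no compound shown goes against this: the limit of > 40000 nM in this assay, at which 2 of the 4 values shown sit.

Compound 1 and compound 4 are both limits and the step between them cannot be read, so the two phenyl-type groups cannot be ordered. Also open, on these data alone, is whether a longer chain, or a cyclohexyl carrying an amine or a carboxylic acid, on this nitrogen would give a lower number than compound 3.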